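Fluoro in place of hydrogen on a benzyl arm

The source may hold more compounds than are shown below. What is called first, only, known or untested is meant among the compounds shown, and "the series" means these compounds.

Compound 1, `Cc1ccc2cc(CN(Cc3ccc(Cl)cc3)Cc3ccc(Cl)cc3)c(=O)[nH]c2c1`: > 33000 nM
Compound 2, `Cc1ccc2cc(CN(Cc3ccc(F)cc3)Cc3ccc(C(C)(C)C)cc3)c(=O)[nH]c2c1`: > 33000 nM
Compound 3, `Cc1ccc2[nH]c(=O)c(CN(Cc3ccccc3)Cc3ccc(C(C)(C)C)cc3)cc2c1`: > 5000 nM

All three compounds were tested in a toxicity assay on MDCK cells (Canis lupus familiaris) for cytotoxicity, read by crystal violet staining, with a stated time of 48 h; a lower number here means that less compound is tolerated, a higher number that more compound is tolerated. Compound 1 reaches only a limit of the assay, > 33000 nM, and not a number. Compound 2 likewise stops at a limit, > 33000 nM. Compound 3 stands at a limit as well, > 5000 nM, which is a different limit from the other two, so the three values cannot be ranked against one another; they agree only in that no half-maximal cytotoxic concentration was reached in the range covered, as the limit of > 33000 nM in this assay, at which 2 of the 3 values shown sit, and the limit of > 5000 nM in this assay, at which 1 of the 3 values shown sits, show.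

Compound 4, `Cc1ccc2[nH]c(=O)c(CN(Cc3ccc(F)cc3)Cc3ccc(C(C)(C)C)cc3)cc2c1`, has not yet been measured in this assay. It differs from compound 3 by fluoro in place of hydrogen on an aromatic carbon. Compound 2 carries the same 4-fluorobenzyl arm alongside the tert-butyl benzyl arm and gave only a limit in this assay. Among the measured compounds shown here, no measured pair in this set isolates the effect of the fluoro, so no step size can be read from the data. Compound 4 is therefore expected to behave like compound 3, with a step that the limit leaves unreadable from compound 3 to compound 4 that stays within the scatter. The estimate for compound 4 is 40000 nM, within the range 8000 nM to 200000 nM, most likely reported again as a limit.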

Compound 4, half-maximal cytotoxic concentration: > 27000 nM
Compound 4 ended at the assay's limit (the forecaster's own chance of this, stated with the estimate: 85%); the middle value does not contradict the limit.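

In this assay, compound 3 and compound 4 each end at a limit of the assay and not at a number, so the effect of fluoro in place of hydrogen on the benzyl arm cannot be read. The compounds shown leave open the concentration at which any of them would reach a half-maximal cytotoxic effect.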